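Replacing a branched amine chain with a cyclohexylmethylamine

A few compounds are considered here, and "the series" means these few. Any claim that something is new, unique, unknown or untested is made for them only; others in the source may bear on it.

Of the compounds shown here, two sharing one core have been measured in a functional assay for agonist activity at G protein-coupled receptor 88 (Homo sapiens), read by HTRF and cAMP accumulation; on this read-out lower numbers stand for an effect already at smaller amounts and higher numbers for an effect only at larger amounts of compound. Compound 1 `CC[C@H](C)[C@@H](CN(C(=O)[C@@H]1C[C@H]1c1ccccc1)c1ccc(-c2ccccc2)cc1)NC(C)=O` gives 5.8 nM in this assay. Compound 2 `CC(C)C[C@H](N)CCN(C(=O)[C@@H]1C[C@H]1c1ccccc1)c1ccc(-c2ccccc2)cc1` gives 3 nM, the lowest of the two numbers, although the step of a 1.9-fold lower number from compound 1 to compound 2 (0.29 log units; within the scatter) is too small to separate the two. That single step shows that the side chain on the saturated carbon bound to the amide-type nitrogen can be rebuilt without a change beyond the scatter.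

Compound 3 `O=C([C@@H]1C[C@H]1c1ccccc1)N(CCNCC1CCCCC1)c1ccc(-c2ccccc2)cc1` takes this further: the difference from compound 2 is (cyclohexylmethyl)amino in place of 1-amino-3-methylbutyl on a saturated chain carbon, two bonds along the chain from an amide-type nitrogen. For the measured compounds named here, the only step on record, from compound 1 to compound 2, touched the same chain and stayed within the scatter, so the chain appears tolerant, but no measured pair speaks to swapping a branched chain for a ring-bearing one or to moving the amine further along. A modest loss in this assay is therefore expected, with wide uncertainty, as the step of a 2.7-fold higher number from compound 2 to compound 3 (0.43 log units; beyond the scatter). Compound 3 is estimated to give 8 nM in this assay, within a range from 1.5 nM to 40 nM.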

Compound 3, half-maximal effective concentration: 6.6 nM
Estimate against measurement, compound 3: 1.2-fold (0.08 log units) above; measured number inside the range.
By their numbers in this assay, from the lowest: compounds 2, 1 and 3 (each within the scatter of the next, the first and the last beyond it).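

In this assay, putting (cyclohexylmethyl)amino in place of 1-amino-3-methylbutyl on a saturated chain carbon, two bonds along the chain from an amide-type nitrogen, gives a 2.2-fold higher number from compound 2 to compound 3 (0.34 log units; beyond the scatter), a modest step and the first on this chain to pass beyond the scatter. The change from the acetamide-bearing side chain gives a 1.1-fold higher number from compound 1 to compound 3 (0.06 log units; within the scatter), which sets the new chain apart from that one by nothing the assay can resolve, so a chain carrying a six-membered carbon ring is accepted here, at least in this single example. No data on hand explain the modest step seen with compound 3.

The ring and the place of the amine change together in compound 3, so the compounds shown cannot say how much of the step belongs to each. From the compounds shown here alone, it also stays open whether a benzylamino group, with an aromatic ring in place of the cyclohexyl ring, or a longer chain such as 3-((cyclohexylmethyl)amino)propyl would keep the number in the same range.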